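Taking one chloro group off compound 2

The source may hold more compounds than are shown below. What is called first, only, known or untested is meant among the compounds shown, and "the series" means these compounds.

In a functional assay on U-87MG ATCC cells for antiproliferative activity against U-87 MG (Homo sapiens), read by MTT assay, with a stated time of 48 h (on this read-out higher numbers stand for weaker inhibition and lower numbers for stronger inhibition), compound 1 (`Cc1nc(-c2ccc(Cl)cc2)sc1C(=O)CSc1nc(-c2cccc(Cl)c2)c(C#N)c(=O)[nH]1`) gives 40100 nM and compound 2 (`Cc1nc(-c2ccccc2)sc1C(=O)CSc1nc(-c2ccc(Cl)c(Cl)c2)c(C#N)c(=O)[nH]1`) gives 65000 nM as its value, so these two stand within the usual scatter of each other. Compound 3 (`Cc1nc(-c2ccccc2)sc1C(=O)CSc1nc(-c2cccc(Cl)c2)c(C#N)c(=O)[nH]1`) is still unmeasured. It carries hydrogen in place of chloro on an aromatic carbon, turning 3,4-dichlorophenyl into 3-chlorophenyl (hydrogen in place of chloro on an aromatic carbon). Going by the values given here, no measured pair shows this change on its own, so no step beyond the scatter is expected in this assay here. For compound 3 the estimated value is 50000 nM with an expected range from 25000 nM to 100000 nM in this test.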

Compound 3, half-maximal inhibitory concentration: 28200 nM
Beside the measured number, compound 3's estimate is 1.8-fold (0.25 log units) above it, and the stated range covers the measured number.
By their numbers in this assay, from the lowest: compounds 3, 1 and 2 (each within the scatter of the next, the first and the last beyond it).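

In this assay, changing 3,4-dichlorophenyl to 3-chlorophenyl gives a 2.3-fold lower number from compound 2 to compound 3 (0.36 log units; beyond the scatter), a modest step showing that this chloro group, ortho to a chloro group, is not needed for activity and that hydrogen serves better here. The same kind of swap at another aromatic carbon gives a 1.4-fold lower number from compound 1 to compound 3 (0.15 log units; within the scatter), so that chloro makes no clear difference. Nothing measured here explains either result. Going by these compounds, whether an amine, a methoxy group or a fluoro group on this carbon would outperform hydrogen remains open, as does the role of the remaining chloro group.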